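A few compounds are considered here, and "the series" means these few. Any claim that something is new, unique, unknown or untested is made for them only; others in the source may bear on it.

In a functional assay on A549 cells (Homo sapiens) for antiproliferative activity, read by sulforhodamine B assay, with a stated time of 72 h (a lower number here means a stronger inhibitor, a higher number a weaker inhibitor), compound 1 (`COc1cc(/C=C2\CCC=CC2=O)cc(OC)c1OC`) gives 4250 nM and compound 2 (`COc1cc(/C=C2\CCC=C(I)C2=O)cc(OC)c1OC`) gives 4860 nM. Compound 3 (`COc1cc(/C=C2\CNC=CC2=O)cc(OC)c1OC`) gives > 25000 nM, which is a limit and not a number. From the compounds shown here alone, it is the only case of the limit of > 25000 nM in this assay, at which 1 of the 3 values shown sits, so its true value is unknown.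

Compound 4 (`COc1cc(/C=C2\CN(S(=O)(=O)c3ccc(C)cc3)C=CC2=O)cc(OC)c1OC`) differs from it by (4-methylphenyl)sulfonyl in place of hydrogen on an amine nitrogen in a ring, with (4-methylphenyl)sulfonyl in place of hydrogen on an amine nitrogen in a ring. Going by the values given here, the only measured step, iodo in place of hydrogen on a double-bonded ring carbon, is a 1.1-fold higher number from compound 1 to compound 2 (0.06 log units; within the scatter). It involves another group at another place, so it offers only weak guidance and does not test this nitrogen. Compound 1 has no hydrogen-bearing ring nitrogen and reaches a measurable 4250 nM, so a similar measurable value seems plausible once that hydrogen is replaced. The expected change is an at least 7.1-fold lower number from compound 3 to compound 4 (0.85 log units; beyond the scatter), toward a lower number, though its size is uncertain. Compound 4 is estimated at 3500 nM, with an expected range of 600 nM to 20000 nM.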

Compound 4, half-maximal inhibitory concentration: 20200 nM
Estimate against measurement, compound 4: 5.8-fold (0.76 log units) below, and the stated range ends below it.
By their numbers in this assay, from the lowest: compounds 1 and 2 (each within the scatter of the next); then compound 4. At a limit, above all of these: compound 3.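

Compound 3 gives > 25000 nM in this assay, which is a limit and not a number. With (4-methylphenyl)sulfonyl in place of hydrogen on the amine nitrogen in the ring, compound 4 gives a measurable value of 20200 nM, so this nitrogen can carry a large group and still give a reading, and the step is an at least 1.2-fold lower number from compound 3 to compound 4 (0.09 log units; that floor lies within the scatter). The true size of this step cannot be read, and a real change cannot be confirmed, because one end of it is a limit: the limit of > 25000 nM in this assay, at which 1 of the 4 values shown sits.

The compounds shown have only hydrogen or (4-methylphenyl)sulfonyl on this nitrogen. From the compounds shown here alone, how a methyl group or a longer alkyl chain there would read in this assay remains open, as does whether the sulfonyl part or the aromatic ring of the group accounts for the reading of compound 4.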